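Chloro on the phenyl of compound 1

The compounds below may be only part of what the source reports. "The series", "measured", "known", "first", "only" and "open" are said of these compounds alone.

Values in a functional assay on K562 cells (Homo sapiens) for inhibition, read by sulforhodamine B assay, with a stated time of 48 h (on this read-out lower numbers stand for stronger inhibition of growth and higher numbers for weaker inhibition of growth), so far:
- compound 1 `CC(C)(C)NCc1c(C(=O)O)nn(-c2ccccc2)c1-c1ccc(Cl)cc1` gives 364000 nM as a number
- compound 2 `COc1ccc(-c2c(CNC(C)(C)C)c(C(=O)O)nn2-c2ccccc2)cc1` gives > 659000 nM as a limit

Going by the values given here, compound 1 holds the only actual number, and the one further value is a limit. Compound 3 `CC(C)(C)NCc1c(C(=O)O)nn(-c2ccc(Cl)cc2)c1-c1ccc(Cl)cc1` differs from compound 1 by chloro in place of hydrogen on an aromatic carbon as chloro in place of hydrogen on an aromatic carbon. Among the compounds with values here, the only measured step of an at least 1.8-fold higher number from compound 1 to compound 2 (0.25 log units; that floor lies within the scatter) is methoxy in place of chloro at another place in the molecule and bears only loosely on this change, so no step beyond the scatter is expected in this assay in either direction. The estimate is a 1.2-fold lower number from compound 1 to compound 3 (0.08 log units; within the scatter) as the expected step. Compound 3 is expected at 300000 nM with an estimated range from 130000 nM to 598000 nM in this read-out.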

Compound 3, concentration for 50% growth inhibition: 290000 nM
Beside the measured number, compound 3's estimate is 1.0-fold (0.01 log units) above it; the measured number falls inside the stated range.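

In this assay, going from phenyl to 4-chlorophenyl gives a 1.3-fold lower number from compound 1 to compound 3 (0.10 log units; within the scatter). Going by these compounds alone, this position therefore takes a chloro without the number moving beyond the scatter, and this is the first step read between two actual numbers rather than against a limit.

Going by these compounds, whether a nitrile or an amine at this place, or an amide in place of the carboxylic acid, would move the number beyond the scatter stays open. Compound 2 remains a limit and offers no number for comparison: the limit of > 659000 nM in this assay, at which 1 of the 3 values shown sits.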